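Thioether and sulfone anilides: fluoro versus trifluoromethyl

The source may report more compounds than this note shows. Statements on the series, on what has been measured and on what is new or still open speak of the compounds shown alone.

Measured compounds in a functional assay on LNCaP cells (Homo sapiens) for antiproliferative activity, read by MTT assay, with a stated time of 96 h; a higher number here means a weaker inhibitor, a lower number a stronger inhibitor:
compound 1 `CC(CSc1ccc(F)cc1)C(=O)Nc1ccc([N+](=O)[O-])cc1C(F)(F)F`: 43200 nM
compound 2 `CC(CSc1ccc(C(F)(F)F)cc1)C(=O)Nc1ccc([N+](=O)[O-])cc1C(F)(F)F`: 54300 nM
compound 3 `CC(CS(=O)(=O)c1ccc(F)cc1)C(=O)Nc1ccc(C#N)c(C(F)(F)F)c1`: 115000 nM

Compound 1 and compound 2 share a core and differ by trifluoromethyl in place of fluoro on an aromatic carbon; the step is a 1.3-fold higher number from compound 1 to compound 2 (0.10 log units; within the scatter). Compound 3 carries a different core; the difference between the two cores is not broken down here. In this assay compound 3 gives the highest of the three numbers.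

Compound 4 `CC(CS(=O)(=O)c1ccc(C(F)(F)F)cc1)C(=O)Nc1ccc(C#N)c(C(F)(F)F)c1` is not yet measured. It differs from compound 3 by trifluoromethyl in place of fluoro on an aromatic carbon, the same change that separates compound 1 from compound 2. Because that earlier step was a 1.3-fold higher number from compound 1 to compound 2 (0.10 log units; within the scatter), a similarly small step is expected here, a 1.2-fold higher number from compound 3 to compound 4 (0.09 log units; within the scatter). Compound 4 is therefore estimated at 140000 nM, within 70000 nM to 300000 nM.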

Compound 4, half-maximal inhibitory concentration: 58000 nM
Compound 4: the middle estimate sits 2.4-fold (0.38 log units) above what was measured; measured number outside the range, below it.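

In this assay, trifluoromethyl in place of fluoro on the core of compound 3 gives a 2.0-fold lower number from compound 3 to compound 4 (0.30 log units; within the scatter). Set beside the same change on the core of compound 1, the two steps cannot be told apart: the same change on two cores in this assay, a 1.3-fold higher number (0.10 log units; within the scatter) from compound 1 to compound 2 and a 2.0-fold lower number (0.30 log units; within the scatter) from compound 3 to compound 4, 2.5-fold (0.40 log units) apart, within the scatter of two such steps. Among the compounds shown here, this shows no difference between the two cores in their response to the change, but with only two pairs it does not show that the change carries over unaltered to other cores.

Open, going by these compounds, is whether another group in that place, such as an amine or a carboxylic acid, would give a step beyond the scatter. Also open, on these data alone, is how much the thioether and sulfone links and the nitro and nitrile groups each contribute to the difference between the cores.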